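Carbamoylphenyl in place of 2-hydroxyethyl: working notes

This account rests on a few compounds, and the source may have more. Where it says the series, first, only, none or still open, it means among the compounds named here.

In a functional assay on CLL cells (Homo sapiens) for cytotoxicity, read by MTT assay, with a stated time of 48 h (on this read-out higher numbers stand for an effect only at larger amounts of compound and lower numbers for an effect already at smaller amounts), compound 3 `C=C(CC)C(=O)c1ccc(OCC(=O)NCCO)c(Cl)c1Cl` gives > 25000 nM as a limit of the assay and not a number.

In this assay compound 1 `C=C(CC)C(=O)c1ccc(OCC(=O)NC(CS)C(=O)OCC)c(Cl)c1Cl` gives 4800 nM and compound 2 `C=C(CC)C(=O)c1ccc(OCC(=O)Nc2ccc3nc[nH]c3c2)c(Cl)c1Cl` gives 3200 nM with a 1.5-fold lower number from compound 1 to compound 2 (0.18 log units; within the scatter) between them.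

The next structure is compound 4 `C=C(CC)C(=O)c1ccc(OCC(=O)Nc2ccc(C(N)=O)cc2)c(Cl)c1Cl` and it differs from compound 3 by one change: 4-carbamoylphenyl in place of 2-hydroxyethyl on an amide-type nitrogen on the amide-type nitrogen.

Two measured steps end on the same 2-hydroxyethyl group: an at least 5.2-fold higher number from compound 1 to compound 3 (0.71 log units; beyond the scatter) and an at least 7.8-fold higher number from compound 2 to compound 3 (0.89 log units; beyond the scatter) are both beyond the scatter. The second is the nearer precedent, with 1H-benzimidazol-6-yl on that nitrogen in compound 2. Going by the values given here, no measured compound carries 4-carbamoylphenyl, so the transfer rests on these two steps alone.

Leaving 2-hydroxyethyl has gone with lower numbers in both measured pairs, and the same direction is expected here, with compound 4 landing close to compound 1 and compound 2 rather than at the limit. The step expected in this assay is an at least 5.0-fold lower number from compound 3 to compound 4 (0.69 log units; beyond the scatter) as an estimate and not a measurement.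

For compound 4 the estimated value is 5000 nM with an expected range from 1800 nM to 18000 nM in this read-out.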

Compound 4, half-maximal effective concentration: 3700 nM
The estimate for compound 4 lay 1.4-fold (0.13 log units) above the measured number, and the stated range covers the measured number.
By their numbers in this assay, from the lowest: compounds 2, 4 and 1 (each within the scatter of the next). At a limit, above all of these: compound 3.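

In this assay, an at least 6.7-fold lower number from compound 3 to compound 4 (0.82 log units; beyond the scatter) shows that a second aromatic group on the amide-type nitrogen, now a six-membered aromatic ring of carbon only, also moves the series away from the value of compound 3. That value for compound 3 is a limit and not a number, so the size of the step remains a bound: the limit of > 25000 nM in this assay, at which 1 of the 4 values shown sits. Against the other two groups there is no separation, with a 1.2-fold higher number from compound 2 to compound 4 (0.06 log units; within the scatter) and a 1.3-fold lower number from compound 1 to compound 4 (0.11 log units; within the scatter), so compound 4 reaches the level of compound 1 and compound 2 with neither the sulfanyl group of compound 1 nor the 1H-benzimidazol-6-yl of compound 2, and among these four compounds only compound 3 stands apart.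

Still open, as far as these compounds go, is whether the level of compound 4 depends on the carbamoyl group or on the ring alone, a question that a plain phenyl or a 4-carboxyphenyl on the same nitrogen would address. Also open, from the compounds shown here alone, is whether compound 3 stands apart for its hydroxyl or for its short chain, which a 2-aminoethyl group or a longer hydroxyalkyl chain would help to separate.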